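Acrylamide-bearing analogue: chlorine added to the aniline ring

A few compounds are considered here, and "the series" means these few. Any claim that something is new, unique, unknown or untested is made for them only; others in the source may bear on it.

Measured so far in a functional assay on MDA-MB-231 cells (Homo sapiens) for inhibition, read by MTT assay, with a stated time of 72 h; on this read-out higher numbers stand for weaker inhibition and lower numbers for stronger inhibition:
compound 1 `O=C(CSc1nc(Nc2ccccc2)c2ccccc2n1)Nc1ccccc1Cl`: 24400 nM
compound 2 `O=C(CSc1nc(Nc2ccccc2)c2ccccc2n1)Nc1ccc(Cl)cc1`: 17200 nM
compound 3 `C=CC(=O)Nc1cccc(NC(=O)CSc2nc(Nc3cccc(F)c3)c3ccccc3n2)c1`: 8160 nM

Compound 3 gives the lowest of the three numbers in this assay. Its nearest neighbour is compound 2, which lies beyond the scatter above it, and compound 1 lies further still. For the measured compounds named here, the only step within the measured set is a 1.4-fold lower number from compound 1 to compound 2 (0.15 log units; within the scatter), and it falls within the scatter.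

Compound 4 `C=CC(=O)Nc1cccc(NC(=O)CSc2nc(Nc3ccc(F)c(Cl)c3)c3ccccc3n2)c1` has not yet been measured. Compared with compound 3 it differs in one place: 3-chloro-4-fluorophenyl in place of 3-fluorophenyl on a nitrogen on an aromatic ring. Going by the values given here, that step alters the aromatic ring on the ring-bound nitrogen, whereas the one measured step concerns the ring on the amide-type nitrogen, so no measured step bears directly on it. Nothing among the three compounds shows what adding a chlorine to that aniline ring does here. With no evidence either way, the expected outcome is a step no larger than the scatter, with at most a slight lean to a lower number, given that compound 3 already gives 8160 nM.

Compound 4 is therefore expected to give 6500 nM in this assay, within a range from 2500 nM to 17000 nM. The estimated step amounts to a 1.3-fold lower number from compound 3 to compound 4 (0.10 log units; within the scatter).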

Compound 4, half-maximal inhibitory concentration: 10600 nM
For compound 4 the middle estimate is 1.6-fold (0.21 log units) below the measured one; measured number inside the range.
By their numbers in this assay, from the lowest: compounds 3, 4, 2 and 1 (each within the scatter of the next, the first and the last beyond it).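

In this assay, for the compounds shown here, the change from (3-fluorophenyl)amino to (3-chloro-4-fluorophenyl)amino gives a 1.3-fold higher number from compound 3 to compound 4 (0.11 log units; within the scatter), the first measured step at this position on a nitrogen on an aromatic ring. The earlier single-place step concerned only the chlorophenyl ring on the amide-type nitrogen, so this result adds separate information: with the acrylamide-bearing part of the molecule unchanged, 3-chloro-4-fluorophenyl and 3-fluorophenyl cannot be told apart on this read-out. No available evidence bears on the reason for this result.

The compounds shown do not separate any contribution of the chlorine from that of the fluorine in 3-chloro-4-fluorophenyl, and a single step cannot define how much change this position tolerates. Going by these compounds, it also remains open whether a different group on this aromatic ring, such as a methoxy group, an amine or a carboxylic acid, would give a step beyond the scatter in this assay, or whether the same exchange would give a similar step in a compound lacking the acrylamide.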